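The compounds below may be only part of what the source reports. "The series", "measured", "known", "first", "only" and "open" are said of these compounds alone.

Measured so far in a functional assay on M14 cells (Homo sapiens) for antiproliferative activity, read by sulforhodamine B assay, with a stated time of 48 h; a higher number here means a weaker inhibitor of growth, a lower number a stronger inhibitor of growth:
- compound 1 `O=C(NCCCNc1cc(-c2cn(-c3ccccc3)nc2-c2cccc(O)c2)ccn1)Nc1ccc(F)cc1`: 5850 nM
- compound 2 `O=C(NCCCNc1cc(-c2cn(-c3ccccc3)nc2-c2cccc(O)c2)ccn1)Nc1cccc(C(F)(F)F)c1`: 6980 nM

Within the data shown here, compound 1 cannot be separated from compound 2 on these numbers, as the only measured step is a 1.2-fold higher number from compound 1 to compound 2 (0.08 log units; within the scatter). That step lies within the scatter.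

Compound 3 `COc1cccc(-c2nn(-c3ccccc3)cc2-c2ccnc(NCCCNC(=O)Nc3ccc(F)cc3)c2)c1` keeps the rest of compound 1 and carries one change: methyl in place of hydrogen on an oxygen on an aromatic ring. This is methyl in place of hydrogen on an oxygen on an aromatic ring, that is, hydroxy to methoxy.

Among the measured compounds shown here, no measured step touches this place. For the measured compounds named here, the one step available, made on an amide-type nitrogen, is only a weak guide. No step beyond the scatter is therefore expected in this assay, and no direction is favoured, though the uncertainty is wide.

The expected step is a 1.1-fold higher number from compound 1 to compound 3 (0.05 log units; within the scatter). For compound 3 the estimated value is 6500 nM, with an expected range of 2800 nM to 16000 nM.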

Compound 3, concentration for total growth inhibition: 19000 nM
Estimate against measurement, compound 3: 2.9-fold (0.47 log units) below; the measured number lies above the stated range.
By their numbers in this assay, from the lowest: compounds 1 and 2 (each within the scatter of the next); then compound 3.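

In this assay the step from hydroxy to methoxy on the 3-hydroxyphenyl group gives a 3.2-fold higher number from compound 1 to compound 3 (0.51 log units; beyond the scatter), so this oxygen is the one place in the series shown so far where a single change moves the number beyond the scatter. Among these compounds, the only earlier step, on an amide-type nitrogen, stayed within the scatter, and so gave no sign that the compounds respond to change at any one site; here, methyl in place of hydrogen on the oxygen weakens growth inhibition. No available evidence bears on what lies behind this loss.

Still open, as far as these compounds go, is whether any group in place of the hydroxy keeps the number of compound 1, for example an amine, or whether a longer chain such as ethoxy weakens inhibition further. From the compounds shown here alone, it is equally open whether methoxy has the same effect when 3-(trifluoromethyl)phenyl replaces 4-fluorophenyl.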